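Working notes: isopropoxy in place of methyl

The compounds below may be only part of what the source reports. "The series", "measured", "known", "first", "only" and "open" are said of these compounds alone.

Measured in a functional assay on the whole organism with Rattus norvegicus as the target; on this read-out higher numbers stand for an effect only at larger amounts of compound and lower numbers for an effect already at smaller amounts
- compound 1 `CCOC(=O)C(=O)Nc1cccc(NC)c1C#N` gives 0.2 mg/kg
- compound 2 `CCOC(=O)C(=O)Nc1cccc(C)c1C#N` gives 5.3 mg/kg

Among the measured compounds shown here, compound 2 stands highest of the two numbers so far. Compound 3 `CCOC(=O)C(=O)Nc1cccc(OC(C)C)c1C#N` differs from it by isopropoxy in place of methyl on an aromatic carbon on an aromatic carbon, ortho to a cyano group. The measured step of a 27-fold higher number from compound 1 to compound 2 (1.42 log units; beyond the scatter) bears on this and also involves methyl at that carbon. Isopropoxy itself has no measured precedent, so only part of that large step is expected back, a moderate move toward a lower number in this assay of this series. For compound 3 1.5 mg/kg is the estimated value, with an expected range of 0.3 mg/kg to 7 mg/kg at this stage. The expected move is a 3.5-fold lower number from compound 2 to compound 3 (0.55 log units; beyond the scatter) for now.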

Compound 3, dose for half-maximal effect: 2 mg/kg
Beside the measured number, compound 3's estimate is 1.3-fold (0.12 log units) below it; the measured number falls inside the stated range.
By their numbers in this assay, from the lowest: compound 1; then compound 3; then compound 2.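

At the aromatic carbon ortho to a cyano group, more than one replacement for methyl lowers the number in this assay: isopropoxy gives a step beyond the scatter (a 2.7-fold lower number from compound 2 to compound 3 (0.42 log units; beyond the scatter)). Isopropoxy still does not match methylamino (a 10-fold higher number from compound 1 to compound 3 (1.00 log units; beyond the scatter)), so compound 1 keeps the lowest number and the order at this carbon is now methylamino, isopropoxy, methyl. No supporting data explain this order.

Open, from the compounds shown here alone, is where methoxy, a primary amino group or dimethylamino would fall at this carbon. Also open, going by these compounds, is whether this order holds with a carboxylic acid in place of the ethyl ester.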